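The source may hold more compounds than are shown below. What is called first, only, known or untested is meant among the compounds shown, and "the series" means these compounds.

In a physicochemical assay for lipophilicity (on this read-out higher numbers stand for higher lipophilicity and lower numbers for lower lipophilicity), compound 2 `Cn1nccc1-c1cc(C(F)(F)F)ccc1[C@H]1CCOc2cc(S(=O)(=O)Nc3nccs3)ccc21` gives 2.2. It stands level with compound 3 `Cn1nccc1-c1cc(C(F)(F)F)ccc1[C@@H]1CCOc2cc(S(=O)(=O)Nc3nccs3)ccc21` at 2.2, and within the scatter of compound 1 `CN1CCN(c2cc(C(F)(F)F)ccc2[C@H]2CCOc3cc(S(=O)(=O)Nc4nccs4)ccc32)CC1` at 2.1. Both measured steps are small: a number 0.10 log units higher from compound 1 to compound 2 (within the scatter), with 1-methyl-1H-pyrazol-5-yl in place of 4-methylpiperazin-1-yl, and no change at the digits printed from compound 2 to compound 3 (within the scatter), a step that rests on (the fact that compounds 2 and 3 differ only in the configuration as drawn). Compound 4 `Cn1nccc1-c1cc(C(F)(F)F)ccc1[C@H]1CCOc2cc(S(=O)(=O)Nc3cnccn3)ccc21` has pyrazin-2-yl in place of 1,3-thiazol-2-yl on a sulfonamide nitrogen. Neither measured step touches that group, so they are only a weak guide, and no direction is favoured. The expected change is no change at the digits printed from compound 2 to compound 4 (within the scatter), with no shift beyond the scatter anticipated. Compound 4 is estimated at 2.2, with an expected range from 1.7 to 2.7.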

Compound 4, distribution coefficient: 1.8
Compound 4: middle estimate off by 0.40 log units, on the high side; measured number inside the range.
By their numbers in this assay, from the lowest: compounds 4, 1, 2 and 3 (each within the scatter of the next, the first and the last beyond it).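

In this assay the group on the sulfonamide nitrogen is shown to matter, with pyrazin-2-yl in place of 1,3-thiazol-2-yl giving a number 0.40 log units lower from compound 2 to compound 4 (beyond the scatter) and so the first step here that clears the scatter. The earlier changes, at another place and in configuration, moved the number by no more than the scatter. Nothing given here explains this step.

Open, as far as these compounds go, is whether the same exchange would move compound 1 or compound 3 by a like amount, and what a pyrimidin-2-yl or a phenyl group on a sulfonamide nitrogen would give.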